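The compounds below may be only part of what the source reports. "The series", "measured", "known", "first", "only" and "open" are said of these compounds alone.

Measured compounds:
compound 1, `COc1ccccc1C(=O)/C=C/c1ccc2c(c1)B(O)OC2`, 5000 nM in a functional assay on HCT-116 cells (Homo sapiens) for cytotoxicity, read by MTT assay, with a stated time of 48 h; on this read-out lower numbers stand for stronger inhibition and higher numbers for weaker inhibition;
compound 2, `COc1cccc(C(=O)/C=C/c2ccc3c(c2)B(O)OC3)c1`, 5000 nM in this assay;
compound 3, `COCOc1ccccc1C(=O)/C=C/c1ccc2c(c1)B(O)OC2`, 10200 nM in this assay.

The three measured compounds share a boron-containing core joined through an enone linker to a substituted phenyl ring. Compound 1 and compound 3 differ in one place only: methoxy in place of hydrogen on a saturated chain carbon bound to an oxygen on an aromatic ring. That change brought a 2.0-fold higher number from compound 1 to compound 3 (0.31 log units; beyond the scatter).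

Compound 2 carries the same atoms as compound 1, joined differently; how the two cores differ is not broken down here. In this assay compound 2 stands level with compound 1 at the digits reported, the two together being the lowest of the three numbers, and compound 3 stands furthest from compound 2.

Compound 4, `COCOc1cccc(C(=O)/C=C/c2ccc3c(c2)B(O)OC3)c1`, has not yet been measured. It relates to compound 2 as compound 3 relates to compound 1: methoxy in place of hydrogen on a saturated chain carbon bound to an oxygen on an aromatic ring. The place of the change is described in the same words for both pairs, so this is the same change made on a second core.

Going by the values given here, with only one earlier example of this change, the step seen from compound 1 to compound 3 is the sole guide, and compound 4 is expected to follow it, giving a 2.0-fold higher number from compound 2 to compound 4 (0.30 log units; within the scatter) as the estimated step. Compound 4 is therefore estimated at 10000 nM in this assay, with a range from 5000 nM to 20000 nM expected to cover the repeat scatter.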

Compound 4, half-maximal inhibitory concentration: 13300 nM
Estimate against measurement, compound 4: 1.3-fold (0.12 log units) below; low and high end bracket the measured number.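

In this assay, the same change on the second core gave a 2.7-fold higher number from compound 2 to compound 4 (0.42 log units; beyond the scatter), so the number rose here as it did on the first core. Set beside the earlier step, the new one runs in the same direction, and the two cannot be told apart in size: the same change on two cores in this assay, a 2.0-fold higher number (0.31 log units; beyond the scatter) from compound 1 to compound 3 and a 2.7-fold higher number (0.42 log units; beyond the scatter) from compound 2 to compound 4, 1.3-fold (0.12 log units) apart, within the scatter of two such steps. Within these two pairs, then, the change carried from one core to the other in both direction and size, but two pairs cannot show that it would carry to a further core, and they do not show why the number rises.

The compounds shown leave open how the number would move if the methoxy were replaced by an amine, a carboxylic acid or a longer chain such as ethoxy, or if the oxygen on the aromatic ring carried only a hydrogen, as a free hydroxyl. They also leave open whether the step seen in this assay would hold in any other cell line or read-out, since every number here comes from that single test.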